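The compounds below may be only part of what the source reports. "The series", "measured", "known", "first", "only" and "open" are said of these compounds alone.

In a functional assay on SW1573 cells (Homo sapiens) for antiproliferative activity, read by sulforhodamine B assay, with a stated time of 48 h (on this read-out lower numbers stand for stronger inhibition of growth and higher numbers for weaker inhibition of growth), compound 3 `CCCCCCC(C#CC(=O)OC)O/C=C/C(=O)OC` gives 3300 nM. For the measured compounds named here, this is the higher of the two actual numbers so far, since compound 2 `COC(=O)C#CC(O/C=C/C(=O)OC)C(C)c1ccccc1` gives 1200 nM, a lower number by more than the scatter. Compound 1 `CCCCCCC(C#CC(=O)O)O/C=C/C(=O)OC` reaches only a limit of the assay, > 100000 nM.

The next compound, compound 4 `COC(=O)C#CC(CC(C)C)O/C=C/C(=O)OC`, alters the chain of compound 3: isopropyl in place of pentyl on a saturated chain carbon, two bonds along the chain from an oxygen on an unsaturated carbon and a triple-bonded carbon. In words, isopropyl takes the place of pentyl on a saturated chain carbon, which can also be read as hexyl to isobutyl. Going by the values given here, the only measured step is an at least 30-fold lower number from compound 1 to compound 3 (1.48 log units; beyond the scatter). It is large, but it is a change at another place, and its size rests on (the limit of > 100000 nM in this assay, at which 1 of the 3 values shown sits). Compound 4 keeps that methyl, so this step bears on the change only by suggesting that a measurable number is likely. It gives no size for a change in the chain. The nearest guide is compound 2, which has a different group on that carbon and gives 1200 nM.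

A small move towards a lower number, not beyond the scatter, is therefore expected, and the estimated step is a 1.3-fold lower number from compound 3 to compound 4 (0.12 log units; within the scatter). The expected value for compound 4 is 2500 nM, with an estimated range of 800 nM to 8000 nM.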

Compound 4, concentration for 50% growth inhibition: 380 nM
Compound 4: middle estimate off by 6.6-fold (0.82 log units), on the high side; measured number outside the range, below it.
By their numbers in this assay, from the lowest: compound 4; then compound 2; then compound 3. At a limit, above all of these: compound 1.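

Swapping pentyl for isopropyl on this saturated chain carbon gives an 8.7-fold lower number from compound 3 to compound 4 (0.94 log units; beyond the scatter) in this assay, which shows that the group at this place can shift growth inhibition well beyond the scatter. Compound 2 had already shown a different number with another group on the same carbon, but compound 4 adds that a small, ring-free group can do better there: compound 2 gives 1200 nM, while compound 4 gives 380 nM, the lowest number shown so far. No measurement shown here accounts for the size of this step, so the reason for it remains unknown.

Isopropyl differs from pentyl both in having fewer carbons and in being branched, so the compounds shown leave open which of these two differences goes with the lower number, and a straight propyl group on the same carbon would pull them apart. On these data alone, it is also open how far this carbon tolerates other kinds of group, such as a longer branched chain, a hydroxyl or an amine, and whether any of them would keep a number as low as that of compound 4.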